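A few compounds are considered here, and "the series" means these few. Any claim that something is new, unique, unknown or untested is made for them only; others in the source may bear on it.

The series is read in a functional assay on A549 cells (Homo sapiens) for antiproliferative activity, read by MTT assay, with a stated time of 72 h (a lower number here means a stronger inhibitor, a higher number a weaker inhibitor), and three compounds have numbers or limits so far. For the measured compounds named here, compound 1 `O=C1O[C@H]([C@@H](O)Cn2cc(-c3cc(C(F)(F)F)cc(C(F)(F)F)c3)nn2)C(OCc2ccccc2)=C1OCc1ccccc1` is the only member with a measured number: in this assay compound 1 gives 28900 nM. Compound 2 `O=C1O/C(=C\Cn2cc(-c3cc(F)cc(F)c3)nn2)C(OCc2ccccc2)=C1OCc1ccccc1` reaches only a limit of the assay, and in this assay compound 2 gives > 100000 nM, which is a limit and not a number. Compound 3 `CC(C)(C)OC(=O)N1CCN(C(=S)SCc2cn(C[C@H](O)[C@H]3OC(=O)C(OCc4ccccc4)=C3OCc3ccccc3)nn2)CC1` likewise stops at a limit, giving > 100000 nM in this assay, again a limit rather than a number. Where compound 2 stands is therefore the edge of what the assay reports, shared with compound 3, as stated by the limit of > 100000 nM in this assay, at which 2 of the 3 values shown sit; compound 1 alone sits below that edge.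

The next compound, compound 4 `COc1ccc(-c2cn(C/C=C3\OC(=O)C(OCc4ccccc4)=C3OCc3ccccc3)nn2)cc1`, carries one change relative to compound 2: 4-methoxyphenyl in place of 3,5-difluorophenyl on an aromatic carbon. Going by the values given here, no measured pair shows a step of this kind, so no size can be read from the data. Since compound 2 gives > 100000 nM as a limit, the most that can be expected is that compound 4 comes back with a number rather than a limit; the expected step from compound 2 to compound 4 is an at least 1.2-fold lower number from compound 2 to compound 4 (0.09 log units; that floor lies within the scatter), and compound 4 is estimated at 80000 nM, within 25000 nM to 250000 nM.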

Compound 4, half-maximal inhibitory concentration: > 100000 nM
Compound 4: only a limit was reported; the forecaster's own chance of this, stated with the estimate: 55%; middle value at least 1.2-fold (0.09 log units) away from the limit.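

Compound 4 also stops at a limit, so no step can be read from compound 2 to compound 4, since both sit at the same edge of this assay: the limit of > 100000 nM in this assay, at which 3 of the 4 values shown sit.

The compounds shown leave open how 4-methoxyphenyl and 3,5-difluorophenyl compare on the shared core, and whether either group gives a measurable number in this assay.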